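Pyrrolidinyl and diisopropyl dithiocarbamates on two chromone cores

The source may report more compounds than this note shows. Statements on the series, on what has been measured and on what is new or still open speak of the compounds shown alone.

Compound 1, `O=c1cc(CSC(=S)N2CCCC2)oc2cc(Cl)ccc12`: > 25000 nM, a limit of the assay.
Compound 2, `CC(C)N(C(=S)SCc1cc(=O)c2ccc(Cl)cc2o1)C(C)C`: > 25000 nM, a limit of the assay.
Compound 3, `Cc1ccc2c(=O)c(CSC(=S)N3CCCC3)coc2c1`: 41400 nM.

The three measured compounds were tested in a functional assay on MCF7 cells (Homo sapiens) for antiproliferative activity, read by MTT assay, with a stated time of 72 h; a lower number here means a stronger inhibitor, a higher number a weaker inhibitor. Going by the values given here, compound 3 gives the only actual number, 41400 nM. Compound 1 is reported only as > 25000 nM, which is a limit and not a number. Compound 2 likewise is reported only as > 25000 nM, again a limit. Compound 1 and compound 2 share a core and differ by diisopropylamino in place of pyrrolidin-1-yl on a thiocarbonyl carbon, and the step between them, a step that the two limits leave unreadable from compound 1 to compound 2, cannot be read because of the limit of > 25000 nM in this assay, at which 2 of the 3 values shown sit. Compound 3 carries a different core, and the difference between the two cores is not broken down here.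

Compound 4, `Cc1ccc2c(=O)c(CSC(=S)N(C(C)C)C(C)C)coc2c1`, has not yet been measured. It stands to compound 3 as compound 2 stands to compound 1: the difference is diisopropylamino in place of pyrrolidin-1-yl on a thiocarbonyl carbon, the same change made at the same place. The earlier step is hidden by the two limits, so nothing measured says which way this change moves the read-out. Since compound 3 gives 41400 nM, compound 4 is expected to remain a weak inhibitor, with an expected step of a 1.1-fold higher number from compound 3 to compound 4 (0.04 log units; within the scatter). The estimate for compound 4 in this assay is 45000 nM, within 15000 nM to 120000 nM, with a fair chance that only a limit is reported.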

Compound 4, half-maximal inhibitory concentration: 6600 nM
Beside the measured number, compound 4's estimate is 6.8-fold (0.83 log units) above it; the whole stated range lies above it.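

In this assay, putting diisopropylamino in place of pyrrolidin-1-yl on a thiocarbonyl carbon of the core of compound 3 gives a 6.3-fold lower number from compound 3 to compound 4 (0.80 log units; beyond the scatter), a step beyond the usual scatter of repeated measurements and one that rests on a single change in a single place. The same change on the other core cannot be read, because compound 1 and compound 2 are both reported only at a limit and not as numbers: the limit of > 25000 nM in this assay, at which 2 of the 4 values shown sit. The change is therefore shown to lower the number on one core only, and the series neither confirms nor contradicts that it does the same on the other core, so this single pair establishes no rule that carries from one core to another.

The compounds shown leave open whether the lower number goes with losing the ring or with the two isopropyl groups themselves, a question that diethylamino, piperidin-1-yl or morpholin-4-yl on the same thiocarbonyl carbon could help to settle. They also leave open how the two cores compare with each other on their own, as no pair shown differs in the core alone by a readable step.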